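Aryl replacements on the shared core: compound 4

A few compounds are considered here, and "the series" means these few. Any claim that something is new, unique, unknown or untested is made for them only; others in the source may bear on it.

Compound 1 `CCCCCCCCCCCCCCCCCCNC(=O)[C@H]1CSC(c2c[nH]c3ccccc23)N1` carries 1H-indol-3-yl on a saturated ring carbon of the shared core. In a functional assay on RH7777 cells (Homo sapiens) for antiproliferative activity against RH7777 (Rattus norvegicus), read by sulforhodamine B assay (on this read-out lower numbers stand for stronger inhibition and higher numbers for weaker inhibition), compound 1 returns only a limit, > 20000 nM, so it has no number of its own and sits at the weak end of the measured set. Compound 2 `CCCCCCCCCCCCCCCCCCNC(=O)[C@H]1CSC(c2cccnc2)N1` gives 10500 nM in this assay. Compound 3 `CCCCCCCCCCCCCCCCCCNC(=O)[C@H]1CSC(c2ccc(F)c(Br)c2)N1` gives 20000 nM in this assay.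

Compound 4 `CCCCCCCCCCCCCCCCCCNC(=O)[C@H]1CSC(c2ccc(C)cc2)N1` differs from compound 1 in one place: 4-methylphenyl in place of 1H-indol-3-yl on a saturated ring carbon.

The measured steps that bear on this replacement are small or unreadable: an at least 1.9-fold lower number from compound 1 to compound 2 (0.27 log units; that floor lies within the scatter); a number no higher from compound 1 to compound 3 (the limit leaves the size open); a 1.9-fold higher number from compound 2 to compound 3 (0.28 log units; within the scatter). The closest comparison is the step to compound 3, another six-membered aromatic ring of carbon only in place of 1H-indol-3-yl, whose size cannot be read because compound 1 stands at the limit of > 20000 nM in this assay, at which 1 of the 3 values shown sits. Across all three measured compounds no step exceeds the scatter.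

The step expected from compound 1 to compound 4 is therefore a number no higher from compound 1 to compound 4 (the limit leaves the size open), no change beyond the scatter in this assay. Compound 4 is estimated at 20000 nM in this assay, within 8000 nM to 50000 nM, with a real chance that only a limit is reported.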

Compound 4, half-maximal inhibitory concentration: > 20000 nM
Compound 4: only a limit was reported; the forecaster's own chance of this, stated with the estimate: 45%; the middle value sits exactly at the limit.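

In this assay compound 4 gives > 20000 nM, and this is a limit, not a number. At this saturated ring carbon, 4-methylphenyl therefore joins 1H-indol-3-yl at the limit, so a single six-membered aromatic ring of carbon only, without a hydrogen-bond donor, gives no readable gain over the two-ring indolyl group. Among the compounds shown here, the only step involving compound 4 with a size attached is an at least 1.9-fold higher number from compound 2 to compound 4 (0.27 log units; that floor lies within the scatter). There is also a number no lower from compound 3 to compound 4 (the limit leaves the size open), and the step to compound 4 from compound 1 cannot be read, with compound 4 now sitting at the limit as well: the limit of > 20000 nM in this assay, at which 2 of the 4 values shown sit.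

With four aryl groups shown, none is separated from the others beyond the scatter, so the compounds shown give no ranking of aryl groups at this position. From the compounds shown here alone, it remains open whether an amine or a carboxylic acid in place of the methyl of 4-methylphenyl would bring a value clear of the limit and give this position a readable step.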